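Methyl on the hydroxy oxygen of compound 2

The source may report more compounds than this note shows. Statements on the series, on what has been measured and on what is new or still open speak of the compounds shown alone.

- compound 1 `COc1ccc(CN2C(=O)/C(=C\c3cc(OC)c(OC)c(OC)c3)c3ccccc32)cc1` gives 1700 nM
- compound 2 `COc1cc(/C=C2/C(=O)N(C)c3ccc(O)cc32)cc(OC)c1OC` gives 4900 nM

In a functional assay on cells (Melanoma cell, Homo sapiens) for cytotoxicity, with a stated time of 48 h (a lower number here means a stronger inhibitor of growth, a higher number a weaker inhibitor of growth), compound 2 has the higher of the two numbers (4900 nM). Compound 1 stands lower (1700 nM), and the gap lies beyond the scatter. Compound 3 `COc1ccc2c(c1)/C(=C\c1cc(OC)c(OC)c(OC)c1)C(=O)N2C` is still unmeasured. It differs from compound 2 in one place, hydroxy to methoxy (methyl in place of hydrogen on an oxygen on an aromatic ring): methyl in place of hydrogen on an oxygen on an aromatic ring. For the measured compounds named here, no measured pair shows this change alone. Compound 1 (1700 nM) has no hydroxy group but differs from compound 2 in other places too, which makes it only a weak guide. A small shift towards a lower number in this assay is expected, probably not beyond the scatter (estimated a 1.6-fold lower number from compound 2 to compound 3 (0.21 log units; within the scatter)). For compound 3 the estimate is 3000 nM (expected range 1000 nM to 9000 nM).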

Compound 3, concentration for 50% growth inhibition: 3100 nM
The estimate for compound 3 lay 1.0-fold (0.01 log units) below the measured number; low and high end bracket the measured number.
By their numbers in this assay, from the lowest: compounds 1, 3 and 2 (each within the scatter of the next, the first and the last beyond it).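

In this assay, for the compounds shown here, the change from hydroxy to methoxy, methyl in place of hydrogen on an oxygen on an aromatic ring, gives a 1.6-fold lower number from compound 2 to compound 3 (0.20 log units; within the scatter) and is the first reading of this change on its own. The hydrogen of the hydroxy group is therefore not needed at this position to keep growth inhibition in the range of compound 2, at least for this one pair. No measurement on hand explains this result.

Still open, going by these compounds, is whether this position accepts more than a methyl on the oxygen, such as a longer chain, or an amine in place of the hydroxy group. On these data alone, the reading rests on a single pair on one core, so whether the same change behaves alike on other members also remains open.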